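The source may report more compounds than this note shows. Statements on the series, on what has been measured and on what is new or still open speak of the compounds shown alone.

Compound 1, `C=C(C)[C@@H]1CC=C(Cn2cc(COc3cccc(C4NC(=O)NC(C)=C4C(C)=O)c3)nn2)CC1`: > 100000 nM
Compound 2, `C=C(C)[C@@H]1CC=C(Cn2cc(COc3cc(C4NC(=O)NC(C)=C4C(C)=O)ccc3OC)nn2)CC1`: > 100000 nM
Compound 3, `C=C(C)[C@@H]1CC=C(Cn2cc(COc3cccc(C4NC(=O)NC5=C4C(=O)CC(C)(C)C5)c3)nn2)CC1`: 51600 nM

The three measured compounds were tested in a functional assay on NCI-H460 cells (Homo sapiens) for inhibition, read by sulforhodamine B assay, with a stated time of 48 h; a higher number here means a weaker inhibitor of growth, a lower number a stronger inhibitor of growth. For compound 1 the value > 100000 nM is a limit of the assay and not a number. For compound 2 the value > 100000 nM is likewise a limit. Going by the values given here, compound 3 gives 51600 nM in this assay, the only number among the three; how its core differs from that of compound 1 is not broken down here.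

Compound 2 differs from compound 1 by methoxy in place of hydrogen on an aromatic carbon. The step that the two limits leave unreadable from compound 1 to compound 2 cannot be sized because both of its ends sit at the limit of > 100000 nM in this assay, at which 2 of the 3 values shown sit.

Among the compounds with values here, compound 4, `C=C(C)[C@@H]1CC=C(Cn2cc(COc3cc(C4NC(=O)NC5=C4C(=O)CC(C)(C)C5)ccc3OC)nn2)CC1`, differs from compound 3 by methoxy in place of hydrogen on an aromatic carbon, the same change as the one between compound 1 and compound 2. Since that measured step gave no readable size, the expectation for compound 4 rests on compound 3 and its 51600 nM alone. The step of a 1.3-fold higher number from compound 3 to compound 4 (0.10 log units; within the scatter) is therefore expected to be small. Compound 4 is estimated to give 65000 nM in this assay, with the range 25000 nM to 150000 nM allowing that the assay may again report only a limit.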

Compound 4, concentration for total growth inhibition: > 100000 nM
Compound 4 was reported as a limit; the forecaster's own chance of this, stated with the estimate: 45%; middle value at least 1.5-fold (0.18 log units) from the limit.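

Going by these compounds alone, on the core of compound 3, methoxy in place of hydrogen on an aromatic carbon gives an at least 1.9-fold higher number from compound 3 to compound 4 (0.28 log units; that floor lies within the scatter) in this assay, and this is the only readable instance of the change, though it fixes a floor and not a size. Within the data shown here, that floor does not by itself establish a real difference between the two compounds, and the same change on the core of compound 1 cannot be read, so the two cores offer no pair of sizes to compare. The series therefore shows only that neither methoxy compound gives a number in this assay, not that the change acts alike on both cores: the limit of > 100000 nM in this assay, at which 3 of the 4 values shown sit.

The compounds shown leave open how hydroxy, ethoxy or a chlorine atom would read in place of the methoxy on the core of compound 3. They also leave open whether an amine or a carboxylic acid on that same aromatic ring would give a value clear of the limit.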